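A few compounds are considered here, and "the series" means these few. Any claim that something is new, unique, unknown or untested is made for them only; others in the source may bear on it.

Measured so far:
compound 1 `COc1cc2ncnc(NNC(=S)NC(=O)c3ccccc3F)c2cc1OC`: 12700 nM
compound 2 `O=C(NC(=S)NNc1ncnc2ccccc12)c1ccccc1`: 1490 nM

In a functional assay on CNE-2 cells (Homo sapiens) for cytotoxicity, read by MTT assay, with a stated time of 72 h (on this read-out lower numbers stand for stronger inhibition and higher numbers for weaker inhibition), compound 2 holds the lowest of the two numbers; the nearest, compound 1, lies beyond the scatter above it. Compound 3 `Cc1ccccc1C(=O)NC(=S)NNc1ncnc2ccccc12` keeps the core of compound 2 and differs by methyl in place of hydrogen on an aromatic carbon, a methyl in place of hydrogen on an aromatic carbon, ortho to a large group. Among the measured compounds shown here, no step of this kind between measured compounds is available here, so in this assay no shift beyond the scatter is expected in either direction. Compound 3 is estimated at 1500 nM, range 600 nM to 4000 nM. The expected step of a 1.0-fold higher number from compound 2 to compound 3 (0.00 log units; within the scatter) is small.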

Compound 3, half-maximal inhibitory concentration: 5460 nM
Compound 3: middle estimate off by 3.6-fold (0.56 log units), on the low side; the whole stated range lies below it.
By their numbers in this assay, from the lowest: compound 2; then compound 3; then compound 1.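

In this assay, among the compounds shown here, the change from phenyl to 2-methylphenyl gives a 3.7-fold higher number from compound 2 to compound 3 (0.56 log units; beyond the scatter) and is the first one-place reading. A single methyl on this aromatic carbon, ortho to a large group, is enough to shift the number towards weaker inhibition. Nothing on hand bears on the reason for this shift.

Still open, from the compounds shown here alone, is whether this same carbon would give a similar shift with an amine, a carboxylic acid or a longer chain such as ethyl. Also open, going by these compounds, is whether methyl on another carbon of this ring would behave alike.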